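A few compounds are considered here, and "the series" means these few. Any claim that something is new, unique, unknown or untested is made for them only; others in the source may bear on it.

Of the compounds shown here, three sharing one core have so far been tested in an ADME assay on HaCaT cells (Homo sapiens) for cytotoxicity, read by MTT assay, with a stated time of 72 h; a lower number here means a stronger inhibitor, a higher number a weaker inhibitor. Compound 1 `Cc1ccc(CSc2cc(Cl)c(C)cc2S(=O)(=O)/N=C(\N)n2nc(C)cc2-c2ccccc2)cc1` gives 30000 nM. Compound 2 `Cc1cc(S(=O)(=O)/N=C(\N)n2nccc2-c2ccccc2)c(SCc2ccccc2)cc1Cl` gives 18000 nM, the second highest of the three numbers, and it sits within the scatter of both compound 1 and compound 3. Compound 3 `Cc1cc(-c2ccccc2)n(/C(N)=N/S(=O)(=O)c2cc(C)c(Cl)cc2SCc2ccccc2)n1` gives 10000 nM. The two single changes seen so far are a 3.0-fold lower number from compound 1 to compound 3 (0.48 log units; beyond the scatter) and a 1.8-fold lower number from compound 2 to compound 3 (0.26 log units; within the scatter).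

Compound 4 `Cc1cc(S(=O)(=O)/N=C(\N)n2nccc2-c2ccccc2)c(SCc2ccc(Cl)cc2)cc1Cl` has not yet been measured. Against compound 2 it shows (chloro in place of hydrogen on an aromatic carbon), the change sitting para to a large group. Among the measured compounds shown here, only one measured step touches that same ring: hydrogen in place of methyl on an aromatic carbon gave a 3.0-fold lower number from compound 1 to compound 3 (0.48 log units; beyond the scatter), a modest move. A group entering at that ring could then be expected to move the number the other way, although chloro is not methyl, so the expected step from compound 2 is kept small at a 1.7-fold higher number from compound 2 to compound 4 (0.22 log units; within the scatter). Compound 4 is therefore estimated at 30000 nM, with a range from 12000 nM to 80000 nM.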

Compound 4, half-maximal inhibitory concentration: 12000 nM
Compound 4: the middle estimate sits 2.5-fold (0.40 log units) above what was measured; measured number inside the range.
By their numbers in this assay, from the lowest: compounds 3, 4, 2 and 1 (each within the scatter of the next, the first and the last beyond it).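

In this assay the move from benzylsulfanyl to (4-chlorobenzyl)sulfanyl gives a 1.5-fold lower number from compound 2 to compound 4 (0.18 log units; within the scatter) and so stays within the scatter, which means that chloro at this place, para to a large group, leaves compound 2 and compound 4 indistinguishable. Among the compounds shown here, the one earlier step on this ring gave (a 3.0-fold lower number from compound 1 to compound 3 (0.48 log units; beyond the scatter)) and could be read beyond the scatter, so changes on this ring do not all register alike, although that step has a methyl on the other side of the shared core in both of its compounds. Nothing measured here explains either result.

From the compounds shown here alone, whether chloro would act the same way on compound 3 remains open. So does whether an amine or a carboxylic acid at this place would move the number beyond the scatter.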